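The source may report more compounds than this note shows. Statements on the series, on what has been measured and on what is new or still open speak of the compounds shown alone.

Measured so far:
compound 1 `O=C(NCCCCc1ccccc1)c1cccc(C2SCC(=O)N2c2cccc(F)c2)c1`; in a functional assay on HOS cells (Homo sapiens) for inhibition, read by CCK-8 assay, with a stated time of 72 h, tested at 1 uM (a higher number here means more inhibition at the concentration tested (going by the name of the read-out), a lower number less inhibition), compound 1 gives 84%.
compound 2 `COc1c(F)cccc1N1C(=O)CSC1c1cccc(C(=O)NCCCCc2ccccc2)c1`; in this assay compound 2 gives 9%.

Compound 2 stands lowest of the two numbers. Compound 3 `Cc1cccc(N2C(=O)CSC2c2cccc(C(=O)NCCCCc3ccccc3)c2)c1` differs from it by 3-methylphenyl in place of 3-fluoro-2-methoxyphenyl on an amide-type nitrogen in a ring. Among the compounds with values here, one measured step bears on this, running the other way: a number 75 percentage points lower from compound 1 to compound 2 (beyond the scatter). With the methoxy leaving and a 3-methylphenyl entering, much of that fall should be undone. Compound 3 is therefore expected to show a large rise, a number 61 percentage points higher from compound 2 to compound 3 (beyond the scatter). From the compounds shown here alone, the fluorine leaving at the same time is untested, so the range is kept wide. Compound 3 is estimated at 70%, within 35% to 92%.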

Compound 3, a percentage reported as inhibition, at one concentration (the size of the read-out at that concentration, not a potency): 84%
Beside the measured number, compound 3's estimate is 14 percentage points below it; low and high end bracket the measured number.
By their numbers in this assay, from the lowest: compound 2; then compounds 1 and 3 (each within the scatter of the next).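

In this assay the earlier fall is wholly taken back, with a number 75 percentage points higher from compound 2 to compound 3 (beyond the scatter) on passing from 3-fluoro-2-methoxyphenyl to 3-methylphenyl. Methyl in place of fluoro on this aromatic ring leaves the level in place, with no change at the digits printed from compound 1 to compound 3 (within the scatter) in this read-out. Among the three compounds, only compound 2 carries the methoxy and only compound 2 stands low, so the fall goes with the methoxy and not with either of the other two groups.

From the compounds shown here alone, whether an amine or a carboxylic acid in place of the methyl would hold this level stays open. No measurement at hand gives a reason for the fall with the methoxy.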